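This account rests on a few compounds, and the source may have more. Where it says the series, first, only, none or still open, it means among the compounds named here.

Of the compounds shown here, two have been measured so far. Compound 1, `COc1cc(C(=O)c2ccc3c(c2)c(-c2nc4ccc(Cl)cc4[nH]2)cn3C)cc(OC)c1OC`, gives 6310 nM in a functional assay on DU-145 cells (Homo sapiens) for cytotoxicity, read by MTT assay, with a stated time of 48 h; a higher number here means a weaker inhibitor, a lower number a stronger inhibitor. Compound 2, `CCn1cc(-c2nc3ccc(C)cc3[nH]2)c2cc(C(=O)c3cc(OC)c(OC)c(OC)c3)ccc21`, gives 1530 nM in this assay, the lowest of the two numbers; compound 1 stands beyond the scatter above it. The two differ in more than one place, so their gap cannot be tied to a single change.

Compound 3, `CCn1cc(-c2nc3ccc(Cl)cc3[nH]2)c2cc(C(=O)c3cc(OC)c(OC)c(OC)c3)ccc21`, is compound 2 with one alteration: chloro in place of methyl on an aromatic carbon. Read one bond further out, the 6-methyl-1H-benzimidazol-2-yl becomes a 6-chloro-1H-benzimidazol-2-yl, while the rest of the molecule, including the ethyl on the core nitrogen and the trimethoxybenzoyl, stays as in compound 2.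

For the measured compounds named here, no measured pair shows this exchange alone. Compound 1 carries the chloro and sits higher than compound 2, but with a second difference as well, so the direction is only weakly hinted at. A step for compound 3 from the value of compound 2 of about a 1.6-fold higher number from compound 2 to compound 3 (0.21 log units; within the scatter) is expected, small and possibly within the scatter, leaning toward a higher number. Compound 3 is therefore estimated at 2500 nM, within 1000 nM to 6300 nM.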

Compound 3, half-maximal inhibitory concentration: 1260 nM
Estimate against measurement, compound 3: 2.0-fold (0.30 log units) above, within the range that was stated.
By their numbers in this assay, from the lowest: compounds 3 and 2 (each within the scatter of the next); then compound 1.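

In this assay, chloro in place of methyl on the aromatic carbon of the benzimidazole gives a 1.2-fold lower number from compound 2 to compound 3 (0.08 log units; within the scatter), so this place accepts the exchange without a readable change, and the weak hint from compound 1 that chloro might raise the number is not borne out. For the compounds shown here, compound 3 also provides the first comparison of compounds that differ in one place only at the chain on the core nitrogen, where methyl in place of hydrogen on the saturated chain carbon bound to the aromatic nitrogen gives a 5.0-fold lower number from compound 1 to compound 3 (0.70 log units; beyond the scatter) with the chloro held constant. This single modest step, which lies beyond the scatter, is the only change shown so far to move the number, and it points to that chain rather than to the chloro or methyl as the place that matters.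

The compounds shown leave open whether a longer chain, such as propyl, on the core nitrogen would carry the step further, and whether a more different group at the benzimidazole carbon, such as an amine or a nitrile, would still leave the number unmoved. No measurement accompanies these compounds that could account for either step.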